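Replacing a Difluorophenyl Amide with a Methylfuran Amide

A few compounds are considered here, and "the series" means these few. Any claim that something is new, unique, unknown or untested is made for them only; others in the source may bear on it.

Three compounds share one core and differ only in the group attached to a carbonyl carbon of an amide. Compound 1 `O=C(CCCCc1ccccc1)Nc1ccc(N2CCN(c3ccc(OC[C@@H]4CO[C@@](Cn5cncn5)(c5ccc(Cl)cc5Cl)O4)cc3)CC2)cc1` gives 7010 nM in a functional assay on HepG2 cells (Homo sapiens) for inhibition, read by MTT assay, with a stated time of 48 h (a higher number here means a weaker inhibitor, a lower number a stronger inhibitor), compound 2 `O=C(Nc1ccc(N2CCN(c3ccc(OC[C@@H]4CO[C@@](Cn5cncn5)(c5ccc(Cl)cc5Cl)O4)cc3)CC2)cc1)c1cccc(F)c1` gives 10800 nM, and compound 3 `O=C(Nc1ccc(N2CCN(c3ccc(OC[C@@H]4CO[C@@](Cn5cncn5)(c5ccc(Cl)cc5Cl)O4)cc3)CC2)cc1)c1ccc(F)c(F)c1` gives 19900 nM, the highest number of the three. The steps between them were a 1.5-fold higher number from compound 1 to compound 2 (0.19 log units; within the scatter), a 2.8-fold higher number from compound 1 to compound 3 (0.45 log units; beyond the scatter) and a 1.8-fold higher number from compound 2 to compound 3 (0.27 log units; within the scatter). Compound 4 `Cc1ccc(C(=O)Nc2ccc(N3CCN(c4ccc(OC[C@@H]5CO[C@@](Cn6cncn6)(c6ccc(Cl)cc6Cl)O5)cc4)CC3)cc2)o1` alters the same position: 5-methylfuran-2-yl in place of 3,4-difluorophenyl on a carbonyl carbon. Because a 2.8-fold higher number from compound 1 to compound 3 (0.45 log units; beyond the scatter) and a 1.8-fold higher number from compound 2 to compound 3 (0.27 log units; within the scatter) at this carbonyl carbon moved the number only a little, compound 4 is expected to shift by about as much, a 1.7-fold lower number from compound 3 to compound 4 (0.22 log units; within the scatter), with no clear direction. Compound 4 is estimated at 12000 nM, between 4000 nM and 40000 nM.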

Compound 4, half-maximal inhibitory concentration: 8700 nM
Beside the measured number, compound 4's estimate is 1.4-fold (0.14 log units) above it, within the range that was stated.
By their numbers in this assay, from the lowest: compounds 1, 4, 2 and 3 (each within the scatter of the next, the first and the last beyond it).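

Putting 5-methylfuran-2-yl in place of 3,4-difluorophenyl gives a 2.3-fold lower number from compound 3 to compound 4 (0.36 log units; beyond the scatter), so the change of ring at this carbonyl carbon has a measurable effect, though a modest one. Compound 4 nevertheless stays close to the other two amides, with a 1.2-fold lower number from compound 2 to compound 4 (0.09 log units; within the scatter) and a 1.2-fold higher number from compound 1 to compound 4 (0.09 log units; within the scatter), so a five-membered aromatic ring with one hetero atom is tolerated here. No measurement shown gives a reason for these steps.

As far as these compounds go, whether the methyl group on the furan matters remains open. So does whether a thiophene or pyridine ring on this carbonyl carbon would give a number closer to compound 4 or compound 3.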